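From methyl to trifluoromethoxy at an assay limit

The source may report more compounds than this note shows. Statements on the series, on what has been measured and on what is new or still open speak of the compounds shown alone.

Compound 1 (`Cc1cccc(CNc2ncnc3c2ncn3[C@@H]2O[C@H](CO)[C@@H](O)[C@H]2O)c1`) is the reference point in a functional assay on MCF cells (Homo sapiens) for antiproliferative activity, with a stated time of 72 h; a higher number here means a weaker inhibitor, a lower number a stronger inhibitor. In this assay compound 1 gives > 166000 nM, which is a limit and not a number. In this assay compound 2 (`OC[C@H]1O[C@@H](n2cnc3c(NCc4ccc(F)c(Cl)c4)ncnc32)[C@H](O)[C@@H]1O`) gives > 166000 nM, which is also a limit. The measurements so far therefore stand at the limit of > 166000 nM in this assay, at which 2 of the 2 values shown sit, and compound 1 has no exact position in the series.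

Compound 3 (`OC[C@H]1O[C@@H](n2cnc3c(NCc4cccc(OC(F)(F)F)c4)ncnc32)[C@H](O)[C@@H]1O`) keeps the core of compound 1 and changes one group: trifluoromethoxy in place of methyl on an aromatic carbon, meta to a large group (trifluoromethoxy in place of methyl on an aromatic carbon).

Going by the values given here, one measured step bears on this change: a step that the two limits leave unreadable from compound 1 to compound 2. Its size cannot be read, and it offers no measured gain or loss to carry over. No direction can be assigned, and no step beyond the scatter is expected in this assay. The expected step is a number no higher from compound 1 to compound 3 (the limit leaves the size open). Compound 3 is estimated at 166000 nM, with an expected range of 70000 nM to 300000 nM, and a further limit is the likeliest report.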

Compound 3, half-maximal inhibitory concentration: > 166000 nM
Compound 3 gave a limit, no number (the forecaster's own chance of this, stated with the estimate: 80%); the middle value sits exactly at the limit.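

No new step can be read: compound 1 and compound 3 are both reported only as limits in this assay, so the change from methyl to trifluoromethoxy has no readable size. All values shown stand at one limit: the limit of > 166000 nM in this assay, at which 3 of the 3 values shown sit.

The compounds shown leave open how far any of them lies from that limit.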